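Methyl for Fluoro on the Shared Core

This account rests on a few compounds, and the source may have more. Where it says the series, first, only, none or still open, it means among the compounds named here.

Going by the values given here, compound 1, `Fc1ccc2c(-c3ccc4ccccc4n3)c[nH]c2c1F`, is one of three compounds measured in an ADME assay on microsomes from liver (Homo sapiens) for metabolic stability, using NADPH, with a stated time of 40 min, tested at 2 uM; a lower number here means that the compound disappears faster, a higher number that the compound lasts longer. In this assay compound 1 gives 0.167 h, the lowest of the three numbers. Its nearest neighbour is compound 3, `Fc1cc2c(-c3ccc4ccccc4n3)c[nH]c2c(F)c1F`, which gives 0.25 h; the step of a 1.5-fold higher number from compound 1 to compound 3 (0.18 log units; within the scatter) is a fluoro in place of hydrogen on an aromatic carbon. The furthest is compound 2, `Cc1cccc2c(-c3ccc4cccc(Cl)c4n3)c[nH]c12`, which gives 1.75 h, and differs from compound 1 in more than one place, so no single step can be read from that pair.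

The unmeasured compound 4, `Cc1c(F)ccc2c(-c3ccc4ccccc4n3)c[nH]c12`, differs from compound 1 as follows: methyl in place of fluoro on an aromatic carbon. Among the compounds with values here, none of the measured steps carries this exact change, so the expectation must rest on the wider picture: the only measured single step is within the scatter, while compound 2, which also carries a methyl, stands well above compound 1 in this assay. The author therefore expects a modest rise for compound 4, with the step of a 1.8-fold higher number from compound 1 to compound 4 (0.25 log units; within the scatter) as the estimate. Compound 4 is estimated at 0.3 h, within a range from 0.12 h to 0.8 h.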

Compound 4, half-life: 0.433 h
Estimate against measurement, compound 4: 1.4-fold (0.16 log units) below, within the range that was stated.
By their numbers in this assay, from the lowest: compounds 1, 3 and 4 (each within the scatter of the next, the first and the last beyond it); then compound 2.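

In this assay, going by these compounds alone, the replacement of fluoro by methyl gives a 2.6-fold higher number from compound 1 to compound 4 (0.41 log units; beyond the scatter), and this is the first single change on the shared core whose size lies beyond the scatter, though the step remains modest. The earlier single change, fluoro in place of hydrogen, gave only a 1.5-fold higher number from compound 1 to compound 3 (0.18 log units; within the scatter), so it did not show that one atom exchanged on this part of the core could move the half-life measurably; the new step shows this for the aromatic carbon ortho to a fluoro group, ortho to a fused ring and meta to a fused ring, on the strength of this one pair alone. Nothing given here bears on why the number moves with this change.

The compounds shown leave open whether the higher number belongs to methyl alone or would also appear with an ethyl group, a methoxy group or an amine on the same carbon. They also leave open whether the step would hold on a core lacking the fluoro group that stays in compound 4.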